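A Fluorinated Group Replaces Trimethoxyphenyl at the Carbonyl

The compounds below may be only part of what the source reports. "The series", "measured", "known", "first", "only" and "open" are said of these compounds alone.

In a functional assay on HeLa cells (Homo sapiens) for antiproliferative activity, read by sulforhodamine B assay, with a stated time of 48 h (on this read-out lower numbers stand for stronger inhibition and higher numbers for weaker inhibition), compound 3 `COc1cc(OC)c2sc(-c3ccc(N/C=C\C(=O)c4cc(OC)c(OC)c(OC)c4)c(C)c3)nc2c1` gives 16400 nM. That places it level with compound 1 `COc1cc(OC)c2sc(-c3ccc(N/C=C\C(=O)c4ccc(OC)c(O)c4)c(C)c3)nc2c1` at 16100 nM. Both numbers stand well above that of compound 2 `COc1ccc(C(=O)/C=C\Nc2ccc(-c3nc4cc(OC)c(OC)c(OC)c4s3)cc2C)cc1F` at 1200 nM, so compound 3 belongs to the weaker end of this small set.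

Compound 4 `COc1cc(OC)c2sc(-c3ccc(N/C=C\C(=O)c4ccc(OC)c(F)c4)c(C)c3)nc2c1` shares the core of compound 3, and one group changes: 3-fluoro-4-methoxyphenyl takes the place of 3,4,5-trimethoxyphenyl on a carbonyl carbon (3-fluoro-4-methoxyphenyl in place of 3,4,5-trimethoxyphenyl on a carbonyl carbon).

Among the compounds with values here, one measured step touches that same place: a 1.0-fold higher number from compound 1 to compound 3 (0.01 log units; within the scatter). It stays within the scatter, so that exchange of groups left the number unmoved. Compound 2 offers a different hint. It already carries 3-fluoro-4-methoxyphenyl on its carbonyl carbon and gives 1200 nM, but its core is not the core of compound 4, so the data cannot show how much of that low number goes with the group alone.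

A moderate move toward stronger inhibition therefore seems more likely than a full match with that low number, and no change at all remains possible. The expected step is a 3.3-fold lower number from compound 3 to compound 4 (0.52 log units; beyond the scatter) in this assay. For compound 4 the estimate is 5000 nM, with an expected range from 1300 nM to 17000 nM.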

Compound 4, half-maximal inhibitory concentration: 14700 nM
Estimate against measurement, compound 4: 2.9-fold (0.47 log units) below, within the range that was stated.
By their numbers in this assay, from the lowest: compound 2; then compounds 4, 1 and 3 (each within the scatter of the next).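

In this assay, a 1.1-fold lower number from compound 3 to compound 4 (0.05 log units; within the scatter) and a 1.1-fold lower number from compound 1 to compound 4 (0.04 log units; within the scatter), so on this shared core 3,4,5-trimethoxyphenyl, 3-hydroxy-4-methoxyphenyl and 3-fluoro-4-methoxyphenyl on the carbonyl carbon all give numbers within the scatter of one another, and the read-out does not tell these three groups apart. Within the data shown here, the hint from compound 2 now reads differently: a 12-fold higher number from compound 2 to compound 4 (1.09 log units; beyond the scatter), a large step in which the only change is hydrogen in place of methoxy on an aromatic carbon, so the low number of compound 2 goes with that methoxy on the core and not with 3-fluoro-4-methoxyphenyl alone. No measurement at hand explains why the carbonyl-side exchanges leave the number level or why the core exchange moves it so far.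

Still open, going by these compounds, is whether the same three groups would stay level on the core of compound 2, where the number is low and differences between them might show more clearly. Also open, on these data alone, is whether a quite different group on the carbonyl carbon, such as a ring bearing an amine or a carboxylic acid, would move the number at all.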